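Amino for chloro on the long-chain member

The source may report more compounds than this note shows. Statements on the series, on what has been measured and on what is new or still open speak of the compounds shown alone.

compound 1 `CCCCCC(CCO)n1cnc2c(N)nc(Cl)nc21` gives > 50000 nM as a limit
compound 2 `CCCCCCCC(CCO)n1cnc2c(N)nc(Cl)nc21` gives > 50000 nM as a limit
compound 3 `CCCCCCCCC(CCO)n1cnc2c(Cl)nc(Cl)nc21` gives 24000 nM as a number

Among the compounds with values here, in a functional assay on SW480 cells (Homo sapiens) for antiproliferative activity, read by MTT assay, with a stated time of 48 h (on this read-out higher numbers stand for weaker inhibition and lower numbers for stronger inhibition), compound 3 gives 24000 nM as the only number of the set. The other two values are limits. The rest of the set rests on the limit of > 50000 nM in this assay, at which 2 of the 3 values shown sit, and nothing finer.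

Compound 4 `CCCCCCCCC(CCO)n1cnc2c(N)nc(Cl)nc21` keeps the chain of compound 3 and differs by amino in place of chloro on an aromatic carbon in the core: amino in place of chloro on an aromatic carbon. Within the data shown here, the one measured step is a step that the two limits leave unreadable from compound 1 to compound 2 and it lies in the chain, so it gives no size to carry over to this change. Among the measured compounds shown here, no measured step covers amino in place of chloro directly.

Compound 2 carries the same amino group and gives > 50000 nM as a limit. Compound 1 carries it too and gives > 50000 nM as a limit. Weaker inhibition is therefore the expected direction in this assay for compound 4, although its chain differs from those of compound 1 and compound 2, and a limit instead of a number is quite possible. The expected step is a 2.3-fold higher number from compound 3 to compound 4 (0.36 log units; beyond the scatter) in that direction. For compound 4 the estimate is 55000 nM with 25000 nM to 120000 nM as the expected range.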

Compound 4, half-maximal inhibitory concentration: 13100 nM
Compound 4: middle estimate off by 4.2-fold (0.62 log units), on the high side; the whole stated range lies above it.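

In this assay, amino in place of chloro on this aromatic carbon gives a 1.8-fold lower number from compound 3 to compound 4 (0.26 log units; within the scatter), so on this chain the two groups cannot be told apart. The amino group therefore does not by itself go with the weak read-out of the shorter-chain members, since among the amino members methyl in place of hydrogen on the chain gives an at least 3.8-fold lower number from compound 2 to compound 4 (0.58 log units; beyond the scatter), and propyl in place of hydrogen on the chain gives an at least 3.8-fold lower number from compound 1 to compound 4 (0.58 log units; beyond the scatter). Among these amino members the chain is what separates the values, but both of these steps start from a limit and not from a number, and the step between compound 1 and compound 2 cannot be read: the limit of > 50000 nM in this assay, at which 2 of the 4 values shown sit.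

On these data alone, whether chloro and amino also stay level on the shorter chains remains open, as does whether a methylamino or methoxy group on the same aromatic carbon would hold the level of compound 4. Also open, as far as these compounds go, is whether a longer chain, or a carboxylic acid in place of the terminal hydroxyl, would lower the number further.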